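Three Ureas at the Assay Limit, a Fourth Expected There

This account rests on a few compounds, and the source may have more. Where it says the series, first, only, none or still open, it means among the compounds named here.

Three compounds built on one shared core were examined in an ADME assay on BJ cells (Homo sapiens) for cytotoxicity, with a stated time of 72 h; on this read-out higher numbers stand for an effect only at larger amounts of compound and lower numbers for an effect already at smaller amounts. Compound 1 `Cc1cc(NC(=O)Nc2cccc([N+](=O)[O-])c2)c2ccccc2n1` gave no number in this assay, only a limit of > 25000 nM. Compound 2 `COc1ccc(NC(=O)Nc2cc(C)nc3ccccc23)cc1OC` likewise returned only a limit, > 25000 nM. Compound 3 `Cc1cc(NC(=O)Nc2ccc(N(C)C)cc2)c2ccccc2n1` also came back as a limit, > 25000 nM. Every value shown thus rests at the limit of > 25000 nM in this assay, at which 3 of the 3 values shown sit, so compound 3 stands exactly where compounds 1 and 2 stand, and none of the three can be told apart from the others on these data.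

The account now turns to compound 4 `Cc1cc(NC(=O)Nc2ccc(Cl)cc2)c2ccccc2n1`, which has not yet been measured in this assay. Compound 4 differs from compound 3 in one place: chloro in place of dimethylamino on an aromatic carbon. Going by the values given here, no step between two measured compounds exists here, so nothing yet shows how any change on this core moves the read-out in this assay; the only regularity on hand is that each value so far is a limit. The step is therefore expected to be a step that the limit leaves unreadable from compound 3 to compound 4, a step not beyond the usual scatter and most likely ending, once more, at a limit rather than a number. For compound 4 the estimate in this assay is 32000 nM, with a range from 12000 nM to 80000 nM.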

Compound 4, half-maximal effective concentration: > 25000 nM
Compound 4 was reported as a limit; the forecaster's own chance of this, stated with the estimate: 80%; the middle value is on the limit's open side.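

No new step can be read: compound 3 and compound 4 both stand only as limits, so chloro in place of dimethylamino has no readable size. The compounds shown leave open at what concentration any of them would give an effect in this assay, and how changes on the shared core move that read-out.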